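A few compounds are considered here, and "the series" means these few. Any claim that something is new, unique, unknown or untested is made for them only; others in the source may bear on it.

Three compounds share one core and a bromo group on the aromatic ring, differing only in the chain on the oxygen. Compound 1 `CCCCOC1(c2ccc(Br)cc2)SC=C(C)n2c1noc2=O` carries a butoxy group; in a functional assay on A2780/DX3 cells (Homo sapiens) for antiproliferative activity, read by MTT assay, with a stated time of 3 days (a lower number here means a stronger inhibitor, a higher number a weaker inhibitor), compound 1 gives 78000 nM. Compound 2 `COC1(c2ccc(Br)cc2)SC=C(C)n2c1noc2=O` carries a methoxy group. In this assay compound 2 gives > 100000 nM, which is a limit of the assay. Compound 3 `CCCCCOC1(c2ccc(Br)cc2)SC=C(C)n2c1noc2=O` carries a pentoxy group. In this assay compound 3 gives > 100000 nM, also a limit. The step of an at least 1.2-fold higher number from compound 1 to compound 2 (0.10 log units; that floor lies within the scatter) and the step of an at least 1.2-fold higher number from compound 1 to compound 3 (0.10 log units; that floor lies within the scatter) both have floors within the scatter, and the step that the two limits leave unreadable from compound 2 to compound 3 is unreadable, since both ends sit at the limit of > 100000 nM in this assay, at which 2 of the 3 values shown sit.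

Compound 4 `COC1(c2ccc(Cl)cc2)SC=C(C)n2c1noc2=O` differs from compound 2 by chloro in place of bromo on an aromatic carbon. Going by the values given here, no measured step touches this aromatic position; all three measured compounds vary only the chain on the oxygen. The expectation therefore rests on compound 2 itself, which in this assay gives > 100000 nM, a limit. Compound 4 is expected to give about 150000 nM, within 60000 nM to 400000 nM, most likely reported again as a limit. The step that the limit leaves unreadable from compound 2 to compound 4 is expected to stay within the scatter.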

Compound 4, half-maximal inhibitory concentration: 113000 nM
Estimate against measurement, compound 4: 1.3-fold (0.12 log units) above; the measured number falls inside the stated range.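

No size can be read for the change from compound 2 to compound 4, because the value of compound 2 is a limit and not a number: the limit of > 100000 nM in this assay, at which 2 of the 4 values shown sit.

The compounds shown leave open whether chloro in place of bromo on an aromatic carbon changes activity at all.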